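Halogen swap on a phenyl triazole amide

The source may report more compounds than this note shows. Statements on the series, on what has been measured and on what is new or still open speak of the compounds shown alone.

Compound 1 `CC(C)n1ncc2c(C(=O)NCc3cn(-c4ccccc4)nn3)cccc21` gives only a limit in a functional assay on MGC-803 cells (Homo sapiens) for inhibition, read by MTT assay, with a stated time of 72 h; a lower number here means a stronger inhibitor, a higher number a weaker inhibitor: > 40000 nM.
Compound 2 `Cc1ccc(-n2cc(CNC(=O)c3cccc4c3cnn4C(C)C)nn2)c(C)c1` gives only a limit in this assay: > 40000 nM.
Compound 3 `CC(C)n1ncc2c(C(=O)NCc3cn(-c4ccc(I)cc4)nn3)cccc21` gives only a limit in this assay: > 40000 nM.

All three share one core and differ only in the group on the aromatic nitrogen of the triazole. Because every value sits at the limit of > 40000 nM in this assay, at which 3 of the 3 values shown sit, none of the steps between them can be read: a step that the two limits leave unreadable from compound 1 to compound 2, a step that the two limits leave unreadable from compound 1 to compound 3 and a step that the two limits leave unreadable from compound 2 to compound 3 are all of unreadable size. Compound 3 thus stands at that limit, indistinguishable from the other two on the numbers shown. Compound 4 `CC(C)n1ncc2c(C(=O)NCc3cn(-c4ccc(F)cc4)nn3)cccc21` differs from compound 3 by fluoro in place of iodo on an aromatic carbon. Among the compounds with values here, no measured step bears on this change; all three are unreadable. Because compound 3 sits at the limit of > 40000 nM in this assay, at which 3 of the 3 values shown sit, compound 4 is expected to stay at the limit too, with an estimated step that the limit leaves unreadable from compound 3 to compound 4 of no readable size. Compound 4 is estimated at 60000 nM, within 20000 nM to 200000 nM.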

Compound 4, half-maximal inhibitory concentration: > 40000 nM
Compound 4 ended at the assay's limit; the forecaster's own chance of this, stated with the estimate: 85%; the middle value does not contradict the limit.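

Compound 4 sits at the same assay limit as compound 1, compound 2 and compound 3, so none of its steps to them can be read: the limit of > 40000 nM in this assay, at which 4 of the 4 values shown sit. The compounds shown leave open which change, if any, would bring inhibition into the measurable range.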